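Carboxymethyl to difluoromethyl: estimating a half-life

The compounds below may be only part of what the source reports. "The series", "measured", "known", "first", "only" and "open" are said of these compounds alone.

Of the compounds shown here, three sharing one core have been tested in an ADME assay for pharmacokinetics, read by LC-MS, in phosphate buffer, with a stated time of 120 min, at pH 7.4, tested at 1 uM, in the presence of a further agent that is not named here; a lower number here means that the compound disappears faster, a higher number that the compound lasts longer. Compound 3 `O=C(O)C/C=C/C(=O)Nc1ccccc1` stands at > 8.53 h, which is only a limit and not a number. Compound 1 `O=C(/C=C/CF)Nc1ccccc1` gives > 8.53 h, also a limit. Compound 2 `O=C(/C=C/C(F)(F)F)Nc1ccccc1` gives 0.267 h, a measured number. The step to compound 4 `O=C(/C=C/C(F)F)Nc1ccccc1` is difluoromethyl in place of carboxymethyl on a double-bonded chain carbon bound to a double-bonded chain carbon, with difluoromethyl in place of carboxymethyl. Going by the values given here, two measured steps bear on it, both large: an at least 31-fold higher number from compound 2 to compound 3 (1.50 log units; beyond the scatter), and, among the fluorinated groups, an at least 31-fold lower number from compound 1 to compound 2 (1.50 log units; beyond the scatter). Difluoromethyl belongs to the same series as fluoromethyl and trifluoromethyl, so compound 4 is expected to land part of the way along that drop. For compound 4 a clearly lower number is expected, an estimated at least 5.6-fold lower number from compound 3 to compound 4 (0.75 log units; beyond the scatter). The estimate for compound 4 is 1.5 h, with an expected range of 0.4 h to 6 h.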

Compound 4, half-life: 0.733 h
Beside the measured number, compound 4's estimate is 2.0-fold (0.31 log units) above it; low and high end bracket the measured number.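

In this assay, most of the fall in this fluorinated series already appears with the second fluorine, an at least 11-fold lower number from compound 1 to compound 4 (1.06 log units; beyond the scatter), while the third adds a smaller further fall, seen in reverse as a 2.7-fold higher number from compound 2 to compound 4 (0.44 log units; beyond the scatter). Difluoromethyl also sits well short of carboxymethyl at this position, an at least 11-fold lower number from compound 3 to compound 4 (1.06 log units; beyond the scatter). The two large steps give only a minimum size: the limit of > 8.53 h in this assay, at which 2 of the 4 values shown sit. As far as these compounds go, how long compound 1 and compound 3 actually last therefore stays open. So does the place of a chloromethyl or aminomethyl group on this double-bonded chain carbon.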